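The source may hold more compounds than are shown below. What is called first, only, known or untested is meant among the compounds shown, and "the series" means these compounds.

Working notes on the series. Compound 1 `CC1=C(C(=O)OCc2ccccc2)C(c2ccc(Cl)cc2Cl)NC(=O)N1CCCC(=O)OCc1ccccc1` is the reference point here. In an ADME assay on MCF7 cells (Homo sapiens) for cytotoxicity, read by CellTiter-Glo, with a stated time of 24 h (a higher number here means a weaker inhibitor of growth, a lower number a stronger inhibitor of growth), compound 1 gives only a limit, > 100000 nM. Compound 2 `CC1=C(C(=O)OCc2ccccc2)C(c2ccc(Cl)cc2Cl)NC(=O)N1CCCCC(=O)O` likewise stops at a limit in this assay, > 100000 nM. Compound 3 `COC(=O)CCCN1C(=O)NC(c2ccc(Cl)cc2Cl)C(C(=O)OCc2ccccc2)=C1C` reaches a different limit in this assay, > 300000 nM. Every measured step in this set thus rests on limits alone: a step that the two limits leave unreadable from compound 1 to compound 2, a step that the two limits leave unreadable from compound 1 to compound 3 and a step that the two limits leave unreadable from compound 2 to compound 3 cannot be read in size or direction. Two of the three values sit at the limit of > 100000 nM in this assay, at which 2 of the 3 values shown sit; the third sits at the limit of > 300000 nM in this assay, at which 1 of the 3 values shown sits.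

Compound 4 `COC(=O)CCCCN1C(=O)NC(c2ccc(Cl)cc2Cl)C(C(=O)OCc2ccccc2)=C1C` has not yet been measured in this assay. Relative to compound 1 it shows ((methoxycarbonyl)methyl in place of benzyloxycarbonyl on a saturated chain carbon, three bonds along the chain from an amide-type nitrogen in a ring). The steps that touch the same end of the chain, a step that the two limits leave unreadable from compound 1 to compound 2 and a step that the two limits leave unreadable from compound 2 to compound 3, bear most directly on this change, and both are unreadable, as is the third, a step that the two limits leave unreadable from compound 1 to compound 3. Among the measured compounds shown here, no measured step gives a size or a direction, so no step beyond the scatter can be expected. The step from compound 1 to compound 4 in this assay is therefore expected to be a step that the limit leaves unreadable from compound 1 to compound 4. Compound 4 is expected to give about 200000 nM in this assay, within a range from 100000 nM to 1000000 nM, most probably reported once more as a limit rather than as a number.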

Compound 4, concentration for 50% growth inhibition: > 100000 nM
Compound 4 was reported as a limit (the forecaster's own chance of this, stated with the estimate: 90%); the middle value is on the limit's open side.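

In this assay, among the compounds shown here, compound 4 stops at a limit, so no step to compound 4 from compound 1, compound 2 or compound 3 can be read in size or direction. The compounds shown leave open whether any change at the end of the chain shifts growth inhibition in this assay at all, with none of the four giving a number.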